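This account rests on a few compounds, and the source may have more. Where it says the series, first, only, none or still open, it means among the compounds named here.

Measured in a functional assay on MCF7 cells (Homo sapiens) for inhibition, read by sulforhodamine B assay, with a stated time of 48 h; on this read-out higher numbers stand for weaker inhibition of growth and lower numbers for stronger inhibition of growth:
- Compound 1 `c1cc(NC2=NCCO2)cc(OC2CCCCC2)c1`: 15900 nM
- Compound 2 `c1ccc(COc2ccc(NC3=NCCO3)cc2)cc1`: 11100 nM
- Compound 3 `O=C(CCl)NC(=O)Nc1ccc(C2CCCCC2)cc1`: 1500 nM

Compound 3 stands lowest of the three on these numbers, which makes it the strongest growth inhibitor measured so far in this assay. At 1500 nM, compound 3 lies clearly below compound 2 at 11100 nM and further below compound 1 at 15900 nM, and both gaps are beyond the usual scatter.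

The next compound to be tested is compound 4 `CC(C)(C)c1ccc(NC(=O)NC(=O)CCl)cc1`, which has tert-butyl in place of cyclohexyl on an aromatic carbon. The rest of the structure is unchanged. Among the measured compounds shown here, no measured pair in this small set shows what replacing this group does, so the expectation is an uncertain one. It rests on the single close relative, compound 3 at 1500 nM, and on the modest size of the structural change. Compounds 1 and 2 differ too widely to offer a guide. A small move towards a higher number, meaning somewhat weaker inhibition of growth, seems most likely, and it may not clear the scatter. The expected step is a 1.7-fold higher number from compound 3 to compound 4 (0.22 log units; within the scatter). For compound 4 the estimated value in this assay is 2500 nM, with an expected range from 1000 nM to 6000 nM.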

Compound 4, concentration for 50% growth inhibition: 4800 nM
For compound 4 the middle estimate is 1.9-fold (0.28 log units) below the measured one, within the range that was stated.
By their numbers in this assay, from the lowest: compound 3; then compound 4; then compounds 2 and 1 (each within the scatter of the next).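

In this assay, tert-butyl in place of cyclohexyl on the aromatic carbon gives a 3.2-fold higher number from compound 3 to compound 4 (0.51 log units; beyond the scatter), a step beyond the scatter. Among the compounds shown here, this is the first direct sign that this position responds to a change between two groups made of carbon only, which compounds 1 and 2 could not show, as they differ too widely from compounds 3 and 4. Neither group carries a hydrogen-bond donor, a hydrogen-bond acceptor or a net charge, so the step comes with no change in those counts, while the heavy-atom count and the presence of the ring change together in this one pair; no measured evidence here explains the step.

For the compounds shown here, with only this pair, the separate contributions of the ring and of the heavy-atom count remain unresolved, and a cyclopentyl group or an unbranched butyl chain at the same aromatic carbon would be needed to pull them apart. Going by these compounds, how an amine or a carboxylic acid would fare at this position also stays open, as does the effect of changes elsewhere in the structure, which compounds 3 and 4 share.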